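From Propyl to Butyl on Compound 2

A few compounds are considered here, and "the series" means these few. Any claim that something is new, unique, unknown or untested is made for them only; others in the source may bear on it.

Of the compounds shown here, two on a shared core have numbers so far. In a functional assay on a cell-free system (Platelet, plasma, Oryctolagus cuniculus) for inhibition, with stated times of 5 min and 6 min (a higher number here means a weaker inhibitor, a lower number a stronger inhibitor), compound 1 (`CCCCN1C(=O)COc2cc(CNc3ccccc3)ccc21`) gives 15200 nM in one test series, and compound 2 (`CCCN1C(=O)COc2cc(CNc3cccc(C)c3)ccc21`) gives 13900 nM in the same series. These two values lie within the usual scatter of each other, so compound 2 stands level with compound 1 on the numbers at hand. Within the data shown here, no measured pair isolates a single structural change.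

Compound 3 (`CCCCN1C(=O)COc2cc(CNc3cccc(C)c3)ccc21`) arises from compound 2 through one change (methyl in place of hydrogen on a saturated chain carbon, three bonds along the chain from an amide-type nitrogen in a ring), which is methyl in place of hydrogen on a saturated chain carbon, three bonds along the chain from an amide-type nitrogen in a ring. This reads as propyl to butyl. Compound 1 also carries butyl and gives 15200 nM within the scatter of compound 2, so no shift beyond the scatter is expected in this assay for this change. The estimated size of the change is a 1.1-fold lower number from compound 2 to compound 3 (0.03 log units; within the scatter) in that test. For compound 3 the expected value is 13000 nM within an estimated range of 6500 nM to 26000 nM in this measurement.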

Compound 3, half-maximal inhibitory concentration: 12700 nM
Compound 3: middle estimate off by 1.0-fold (0.01 log units), on the high side; the measured number falls inside the stated range.
By their numbers in this assay, from the lowest: compounds 3, 2 and 1 (each within the scatter of the next).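

In this assay, the propyl-to-butyl change can now be read on its own, and it gives a 1.1-fold lower number from compound 2 to compound 3 (0.04 log units; within the scatter), so adding this methyl to the saturated chain leaves the number within the scatter. Among these compounds, compound 3 also provides the first isolated reading of methyl in place of hydrogen on an aromatic carbon, with a 1.2-fold lower number from compound 1 to compound 3 (0.08 log units; within the scatter), which is likewise within the scatter. Neither single change separates the compounds in this test, and no supporting measurement bears on the result.

The compounds shown leave open whether a longer chain, such as pentyl, or a chain ending in an amine or a carboxylic acid, would move the number beyond the scatter. Among the compounds shown here, they also leave open whether a chlorine, methoxy or trifluoromethyl group in place of the aromatic methyl would do so, since the only comparison here is between hydrogen and methyl on that ring.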